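From ethyl to propyl in compound 3

This account rests on a few compounds, and the source may have more. Where it says the series, first, only, none or still open, it means among the compounds named here.

compound 1 `CCN(CCNC(=O)c1cc(Cl)c(N)cc1OC)Cc1ccc(Cl)cc1`: 0.24 mg/kg
compound 2 `CCN(CCNC(=O)c1cc(Cl)c(N)cc1OC)Cc1ccc(F)cc1`: 0.2 mg/kg

In a functional assay on the whole organism with Rattus norvegicus as the target (on this read-out lower numbers stand for an effect already at smaller amounts and higher numbers for an effect only at larger amounts of compound), compound 1 gives 0.24 mg/kg, and compound 2 gives 0.2 mg/kg. Among the compounds with values here, on these numbers the two compounds cannot be told apart, so compound 1 stands level with its only measured neighbour.

Compound 3 `CCCN(CCNC(=O)c1cc(Cl)c(N)cc1OC)Cc1ccc(Cl)cc1` keeps the core of compound 1 and changes one chain, from ethyl to propyl. The difference is methyl in place of hydrogen on a saturated chain carbon, two bonds along the chain from an amine nitrogen.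

Within the data shown here, only one measured step is available, a 1.2-fold lower number from compound 1 to compound 2 (0.08 log units; within the scatter). It replaces chloro with fluoro on an aromatic carbon, not on this chain, so it bears on the new change only loosely. Among the measured compounds shown here, no measured pair shows what lengthening the chain does, and a single step makes no pattern. With no evidence for either direction, no shift beyond the scatter is expected in this assay. The expected step is a 1.0-fold higher number from compound 1 to compound 3 (0.02 log units; within the scatter). For compound 3 the estimated value is 0.25 mg/kg, with an expected range from 0.09 mg/kg to 0.7 mg/kg.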

Compound 3, dose for half-maximal effect: 3 mg/kg
Compound 3: the middle estimate sits 12-fold (1.08 log units) below what was measured; measured number above the stated range.
By their numbers in this assay, from the lowest: compounds 2 and 1 (each within the scatter of the next); then compound 3.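

In this assay, within the data shown here, the lengthening of the chain from ethyl to propyl gives a 13-fold higher number from compound 1 to compound 3 (1.10 log units; beyond the scatter) and so moves the number far beyond the scatter, while the only earlier step, a 1.2-fold lower number from compound 1 to compound 2 (0.08 log units; within the scatter) on an aromatic carbon, stayed within it. This shows that the dose needed for the effect can respond strongly to a very small edit at this place, on a saturated chain carbon, two bonds along the chain from an amine nitrogen: the entering methyl adds just 1 heavy atom, with no ring, no hydrogen-bond donors or acceptors and no net charge. Nothing available here explains why so small a change has so large an effect.

The compounds shown leave open whether the number would keep climbing with a longer chain such as butyl, or whether a shorter methyl in place of the ethyl would give a number like that of compound 1 or a different one. They also leave open whether the same change from ethyl to propyl would have a similar effect on compound 2, which carries fluoro in place of chloro.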